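A methoxy added to a chlorinated aminophenyl compound

A few compounds are considered here, and "the series" means these few. Any claim that something is new, unique, unknown or untested is made for them only; others in the source may bear on it.

Values measured in a functional assay on MDA-MB-468 cells (Homo sapiens) for inhibition (a lower number here means a stronger inhibitor, a higher number a weaker inhibitor), are as follows.
- Compound 1 `Cc1ccc2nc(-c3ccc(N)cc3Br)sc2c1` gives < 0.1 nM as a limit
- Compound 2 `Nc1ccc(-c2nc3ccccc3s2)cc1Cl` gives < 100 nM as a limit

Neither measured compound has an exact number. In this assay, going by these compounds, compound 2 stands at < 100 nM and this value is a limit, so its true place is unknown. Compound 3 `COc1cccc2sc(-c3ccc(N)c(Cl)c3)nc12` follows from compound 2 with methoxy in place of hydrogen on an aromatic carbon of the fused system. Within the data shown here, no step between measured compounds offers a guide, so the expectation stays broad. The expected change is a step that the limit leaves unreadable from compound 2 to compound 3 and this estimate points to no shift beyond the scatter, in either direction. Compound 3 is expected at 60 nM in this assay with an estimated range from 3 nM to 1000 nM for the measurement still to come.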

Compound 3, half-maximal inhibitory concentration: > 10000 nM
Compound 3 gave a limit, no number (the forecaster's own chance of this, stated with the estimate: 25%); at least 160-fold (2.22 log units) between middle value and limit.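

In this assay, among these compounds, methoxy in place of hydrogen on an aromatic carbon of the fused system gives the first step that can be read between two compounds: an at least 100-fold higher number from compound 2 to compound 3 (2.00 log units; beyond the scatter). This shows that, for this pair, the carbon ortho to a fused ring on the six-membered aromatic ring does not accept methoxy without a large move towards weaker inhibition. Compound 3 gives > 10000 nM, which is a limit, and the step rests on limits at both ends, so it fixes a direction but not a size: the limit of > 10000 nM in this assay, at which 1 of the 3 values shown sits.

The compounds shown leave open whether this shift belongs to methoxy itself or would also follow a smaller group on the same carbon, such as fluorine or hydroxyl. Also open, going by these compounds, is whether methoxy would have the same effect on another carbon of that ring.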